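Thiophene-to-pyridine swap in the triaryl series

A few compounds are considered here, and "the series" means these few. Any claim that something is new, unique, unknown or untested is made for them only; others in the source may bear on it.

Three members of the series have been measured in a functional assay on HCT-15 cells (Homo sapiens) for cytotoxicity, read by CCK-8 assay and cell counting, with a stated time of 2 days; on this read-out higher numbers stand for weaker inhibition and lower numbers for stronger inhibition. Compound 1 `Oc1cccc(-c2cc(-c3ccc(Cl)cc3)nc(-c3cccs3)c2)c1` gives 9280 nM. Compound 2 `Oc1cccc(-c2cc(-c3ccc(Cl)cc3)nc(-c3cccnc3)c2)c1` gives 16800 nM. Compound 3 `Oc1ccc(-c2cc(-c3cccc(Cl)c3)nc(-c3cccs3)c2)cc1` gives 5050 nM. Compound 3 and compound 1 are built from the same atoms joined differently; the difference between the two cores is not broken down here, and their two values lie within the scatter of each other. Compound 3 and compound 2 are separated by more than the scatter.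

One change has been measured directly: pyridin-3-yl in place of thiophen-2-yl on an aromatic carbon, which produced a 1.8-fold higher number from compound 1 to compound 2 (0.26 log units; within the scatter), a step within the scatter.

Compound 4 `Oc1ccc(-c2cc(-c3cccnc3)nc(-c3cccc(Cl)c3)c2)cc1` is not yet measured. It arises from compound 3 by pyridin-3-yl in place of thiophen-2-yl on an aromatic carbon. Going by the values given here, this is the same kind of change as the one from compound 1 to compound 2, not the same: here the place is meta to a 3-chlorophenyl group and meta to a 4-hydroxyphenyl group, whereas in compound 1 it was meta to a 3-hydroxyphenyl group and meta to a 4-chlorophenyl group.

Among the compounds with values here, for compound 4 the expected step is a 1.8-fold higher number from compound 3 to compound 4 (0.25 log units; within the scatter), resting on the single measured instance of this kind of change, a 1.8-fold higher number from compound 1 to compound 2 (0.26 log units; within the scatter). Compound 4 is therefore estimated at 9000 nM in this assay, with a range from 4000 nM to 20000 nM.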

Compound 4, half-maximal inhibitory concentration: 21300 nM
For compound 4 the middle estimate is 2.4-fold (0.37 log units) below the measured one; the whole stated range lies below it.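

In this assay, pyridin-3-yl in place of thiophen-2-yl gives a 4.2-fold higher number from compound 3 to compound 4 (0.63 log units; beyond the scatter) as the new step on this core, so the number rises here as it did on the core of compound 1. This shows that the direction held on both cores examined, but two cores are too few to set a general size for the change or to show that its size depends on the core. The two steps cannot be told apart, so the larger new step is no firm sign of a core effect, and the comparison stands as follows: the same change on two cores in this assay, a 1.8-fold higher number (0.26 log units; within the scatter) from compound 1 to compound 2 and a 4.2-fold higher number (0.63 log units; beyond the scatter) from compound 3 to compound 4, 2.3-fold (0.37 log units) apart, within the scatter of two such steps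

Still open, on these data alone, is how groups other than these two aromatic rings would behave at the same place on the shared core, for example an aminomethyl group, a carboxylic acid or a longer alkyl chain. Also open, as far as these compounds go, is whether the change would keep its direction with the chlorophenyl or hydroxyphenyl group replaced by a phenyl ring carrying a methoxy group or a nitrile.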